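From Hydroxy to Methoxy in a Whole-Animal Series

This account rests on a few compounds, and the source may have more. Where it says the series, first, only, none or still open, it means among the compounds named here.

Of the compounds shown here, three sharing one core have been measured in a functional assay on the whole organism (strain albino) with Mus musculus as the target, with a stated time of 0.5 h; a higher number here means that more compound is needed for the effect, a lower number that less compound is needed. Compound 1 `Cc1ccc(/C=C2/N=C(c3ccccc3)N(C(=O)COc3ccccc3)NC2=O)cc1` gives 300 mg/kg in this assay, compound 2 `O=C1NN(C(=O)c2ccc(Cl)cc2)C(c2ccccc2)=N/C1=C/c1ccccc1` gives 100 mg/kg, and compound 3 `Cc1ccc(C(=O)N2NC(=O)/C(=C\c3ccc(O)cc3)N=C2c2ccccc2)cc1` gives 30 mg/kg. Compound 3 therefore stands at the lowest of the three numbers, needing the least material for the effect; compound 2 sits nearest to it, beyond the scatter, and compound 1 lies furthest, also beyond the scatter. Within the data shown here, none of these three differ in only a single place, so no step between measured compounds can be drawn.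

Compound 4 `COc1ccc(/C=C2/N=C(c3ccccc3)N(C(=O)c3ccc(C)cc3)NC2=O)cc1` has not yet been measured. It differs from compound 3 by methyl in place of hydrogen on an oxygen on an aromatic ring, so the hydroxy becomes a methoxy and the 4-hydroxyphenyl becomes a 4-methoxyphenyl. The two compounds without a hydroxy, compound 1 with 300 mg/kg and compound 2 with 100 mg/kg, both need more material than compound 3, but they differ from it in more than this one place, so they offer no direct guide. The author expects a modest rise in the number from compound 3 to compound 4, estimated as a 2.0-fold higher number from compound 3 to compound 4 (0.30 log units; within the scatter), with a wide spread. For compound 4 the expected value in this assay is 60 mg/kg, with a range from 20 mg/kg to 200 mg/kg.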

Compound 4, dose for half-maximal effect: 100 mg/kg
Estimate against measurement, compound 4: 1.7-fold (0.22 log units) below; low and high end bracket the measured number.
By their numbers in this assay, from the lowest: compound 3; then compounds 2 and 4 (each within the scatter of the next); then compound 1.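

In this assay, among these compounds, methyl in place of hydrogen on an oxygen on an aromatic ring gives a 3.3-fold higher number from compound 3 to compound 4 (0.52 log units; beyond the scatter), the first change in this set that can be read at a single place, and it lies beyond the scatter. The earlier compounds shown here differed from one another in more than one place and could not isolate this position; this step shows that, with the rest of the molecule held constant, going from 4-hydroxyphenyl to 4-methoxyphenyl is enough to raise the amount of compound needed for the effect. The compounds shown offer no independent measurement that would account for this rise, which remains a single observation at one position.

On these data alone, it remains open whether the rise depends on the hydrogen being lost or on the methyl being added, which an ethoxy group, a longer chain on the same oxygen, or an amine in place of the hydroxy could help to separate. As far as these compounds go, it is also open whether the hydroxy-to-methoxy change would give a step of similar size with the other groups carried by compound 1 and compound 2.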